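A few compounds are considered here, and "the series" means these few. Any claim that something is new, unique, unknown or untested is made for them only; others in the source may bear on it.

Measured so far, all in a functional assay on HepG2 cells (Homo sapiens) for inhibition, read by sulforhodamine B assay, with a stated time of 72 h, tested at 10 uM; a higher number here means more inhibition at the concentration tested (going by the name of the read-out), a lower number less inhibition:
- compound 1 `C[C@H](Nc1ncnc2[nH]cnc12)c1nn(-c2cccnc2)c2cc(Cl)ccc12` gives 13%
- compound 2 `C[C@H](Nc1ncnc2[nH]cnc12)c1nn(-c2cccnc2)c2cc(F)ccc12` gives 23%
- compound 3 `C[C@H](Nc1ncnc2[nH]cnc12)c1nn(-c2ccncc2)c2cc(F)ccc12` gives 47%

Compound 2 holds the second highest of the three numbers. Its nearest neighbour is compound 1, the step of a number 10 percentage points higher from compound 1 to compound 2 (within the scatter) lying within the scatter; its furthest is compound 3, the step of a number 24 percentage points higher from compound 2 to compound 3 (beyond the scatter) lying beyond it.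

Compound 4 `CC(C)[C@H](Nc1ncnc2[nH]cnc12)c1nn(-c2cccnc2)c2cc(F)ccc12` differs from compound 2 by isopropyl in place of methyl on a saturated chain carbon bound to an aromatic carbon and a nitrogen on an aromatic ring. Going by the values given here, neither measured step touches this saturated chain carbon: one exchanges a halogen on an aromatic carbon, the other a pyridyl on an aromatic nitrogen, so no measured step bears directly on the change. With nothing to point either way, compound 4 is expected to sit near compound 2, the step of a number 2 percentage points higher from compound 2 to compound 4 (within the scatter) expected to stay within the scatter. Compound 4 is estimated at 25%, range 10% to 45%.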

Compound 4, a percentage reported as inhibition, at one concentration (the size of the read-out at that concentration, not a potency): 16%
Compound 4: the middle estimate sits 9 percentage points above what was measured, and the stated range covers the measured number.
By their numbers in this assay, from the lowest: compounds 1, 4 and 2 (each within the scatter of the next); then compound 3.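

Going by these compounds alone, at the saturated chain carbon bound to an aromatic carbon and a nitrogen on an aromatic ring, isopropyl in place of methyl gives a number 7 percentage points lower from compound 2 to compound 4 (within the scatter) in this assay and is the first reading at this position. With the pyridin-3-yl and fluoro groups of compound 2 held fixed, going from 1 heavy atom to 3 here does not move the number beyond the scatter. No available data explain this result.

From the compounds shown here alone, whether the same exchange reads alike with the pyridin-4-yl group remains open. Also open, going by these compounds, is whether a cyclopropyl, a hydroxymethyl or a longer chain on this carbon would give a step beyond the scatter.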